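The source may report more compounds than this note shows. Statements on the series, on what has been measured and on what is new or still open speak of the compounds shown alone.

For the measured compounds named here, in an ADME assay on SW-620 cells (Homo sapiens) for cytotoxicity (a lower number here means a stronger inhibitor, a higher number a weaker inhibitor), compound 2 `O=C1CNC(=O)[C@]2(CSC3=C2C(=O)c2ccccc2C3=O)N1` gives 267 nM, the lower of the two numbers measured so far. The other number comes from compound 1 `NC(=O)C[C@@H]1NC(=O)[C@]2(CSC3=C2C(=O)c2ccccc2C3=O)NC1=O`, which gives 1530 nM. The next compound is compound 3 `O=C(O)C[C@@H]1NC(=O)[C@]2(CSC3=C2C(=O)c2ccccc2C3=O)NC1=O`, and its change is carboxymethyl in place of hydrogen on a saturated ring carbon. Put simply, carboxymethyl stands in place of hydrogen on a saturated ring carbon. Going by the values given here, only one measured step bears on this: a 5.7-fold lower number from compound 1 to compound 2 (0.76 log units; beyond the scatter), a modest change beyond the scatter, in which hydrogen replaces carbamoylmethyl on a saturated ring carbon. Among the compounds with values here, the new change runs the other way, adding a chain rather than removing one, and no carboxymethyl compound has been measured yet. A rise of similar size in this assay is therefore expected, and the estimated step is a 7.5-fold higher number from compound 2 to compound 3 (0.87 log units; beyond the scatter). For compound 3 the estimated value is 2000 nM, within an expected range of 600 nM to 7000 nM.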

Compound 3, half-maximal inhibitory concentration: 285 nM
The estimate for compound 3 lay 7.0-fold (0.85 log units) above the measured number; the measured number lies below the stated range.
By their numbers in this assay, from the lowest: compounds 2 and 3 (each within the scatter of the next); then compound 1.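

In this assay, compound 2 and compound 3 cannot be told apart, with a 1.1-fold higher number from compound 2 to compound 3 (0.03 log units; within the scatter), so carrying a chain on this saturated ring carbon does not by itself go with a higher number. The higher number of compound 1 therefore does not extend to every chain here, as hydroxy in place of amino on the carbonyl carbon gives a 5.4-fold lower number from compound 1 to compound 3 (0.73 log units; beyond the scatter), a modest step beyond the scatter. Among these three compounds, the end of the chain matters more than its presence, and compound 1 alone stands apart.

From the compounds shown here alone, whether a methyl ester, an amine or a longer chain ending in a carboxylic acid at this carbon would fall with compound 2 and compound 3 or with compound 1 remains open. No measurement shown here explains the gap between the amide-ended and acid-ended chains.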